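Three amides measured, a fourth benzyl amide awaits

This account rests on a few compounds, and the source may have more. Where it says the series, first, only, none or still open, it means among the compounds named here.

In an assay on isolated protein for inhibition of NEDD8-activating enzyme E1 regulatory subunit (Homo sapiens), read by Western blot, with stated times of 10 min and 30 min, tested at 25 uM (on this read-out lower numbers stand for less inhibition and higher numbers for more inhibition at the one concentration tested (going by the name of the read-out)), compound 1 `CCOc1nc2cccc(C(=O)NCCCN(C)C)c2n1Cc1ccc(-c2ccccc2-c2nnn[nH]2)cc1` gives 29.5%, compound 2 `CCOc1nc2cccc(C(=O)Nc3ccc(F)cc3)c2n1Cc1ccc(-c2ccccc2-c2nnn[nH]2)cc1` gives 45.3% and compound 3 `CCOc1nc2cccc(C(=O)Nc3ccncc3)c2n1Cc1ccc(-c2ccccc2-c2nnn[nH]2)cc1` gives 39.8%. Among these three numbers compound 3 stands second highest: the step of a number 5.5 percentage points lower from compound 2 to compound 3 (within the scatter), whereas the step of a number 10.3 percentage points higher from compound 1 to compound 3 (beyond the scatter). Compound 4 `CCOc1nc2cccc(C(=O)NCc3ccc(F)cc3)c2n1Cc1ccc(-c2ccccc2-c2nnn[nH]2)cc1` differs from compound 3 in one place: 4-fluorobenzyl in place of pyridin-4-yl on an amide-type nitrogen. Two kinds of measured step bear on this. Replacing 4-fluorophenyl by pyridin-4-yl on the amide-type nitrogen gave a number 5.5 percentage points lower from compound 2 to compound 3 (within the scatter). Replacing the 3-(dimethylamino)propyl chain by a six-membered aromatic ring gave a number 15.8 percentage points higher from compound 1 to compound 2 (beyond the scatter) and a number 10.3 percentage points higher from compound 1 to compound 3 (beyond the scatter). Compound 4 keeps a six-membered aromatic ring on the amide-type nitrogen, now carried on 4-fluorobenzyl, so for compound 4 in this assay a step of a number 1.2 percentage points higher from compound 3 to compound 4 (within the scatter) is expected, none beyond the scatter. The estimate for compound 4 in this assay is 41%, expected to fall between 27% and 55%.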

Compound 4, a percentage reported as inhibition, at one concentration (the size of the read-out at that concentration, not a potency): 38.1%
Beside the measured number, compound 4's estimate is 2.9 percentage points above it; measured number inside the range.
By their numbers in this assay, from the lowest: compounds 1, 4, 3 and 2 (each within the scatter of the next, the first and the last beyond it).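

In this assay the steps of a number 1.7 percentage points lower from compound 3 to compound 4 (within the scatter) and a number 7.2 percentage points lower from compound 2 to compound 4 (within the scatter) show that 4-fluorobenzyl on the amide-type nitrogen cannot be told apart from pyridin-4-yl or 4-fluorophenyl at this position. New here is the step of a number 8.6 percentage points higher from compound 1 to compound 4 (within the scatter) set against the steps of a number 15.8 percentage points higher from compound 1 to compound 2 (beyond the scatter) and a number 10.3 percentage points higher from compound 1 to compound 3 (beyond the scatter) that lay beyond the scatter. A six-membered aromatic ring on this position therefore does not by itself carry a step from compound 1 beyond the scatter, with compound 4 going against the pattern of compound 2 and compound 3. No measurement given here accounts for any of these steps. The compounds shown leave open how unsubstituted benzyl, a 2-phenylethyl chain or a carboxylic acid on this amide-type nitrogen would read, and whether any such group would stand apart from compound 2 beyond the scatter.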